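Paw edema inhibition: from morpholine to aminophenyl amide

This account rests on a few compounds, and the source may have more. Where it says the series, first, only, none or still open, it means among the compounds named here.

Measured compounds:
compound 1 `O=C(Nc1ccccn1)c1c(O)c2cccnc2n(-c2ccccc2)c1=O` — 14.6%
compound 2 `O=C(NC1CCN(Cc2ccccc2)CC1)c1c(O)c2cccnc2n(-c2ccccc2)c1=O` — 1.2%
compound 3 `O=C(NN1CCOCC1)c1c(O)c2cccnc2n(-c2ccccc2)c1=O` — -26.2%

These three share one core and differ only in the group on the amide-type nitrogen, read in a functional assay on the whole organism for inhibition, with Rattus norvegicus as the target, read by cytopathic effect and paw edema, at a dose of 100 mg/kg by the oral route; a lower number here means less inhibition, a higher number more inhibition at the dose given (going by the name of the read-out). Compound 3 stands lowest of the three, below compound 2 and below compound 1, both gaps beyond the scatter.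

Compound 4 `Nc1ccc(NC(=O)c2c(O)c3cccnc3n(-c3ccccc3)c2=O)cc1` differs from compound 3 by 4-aminophenyl in place of morpholin-4-yl on an amide-type nitrogen. Among the compounds with values here, the only measured step that bears on this is a number 40.8 percentage points lower from compound 1 to compound 3 (beyond the scatter), where a six-membered aromatic ring gave way to morpholin-4-yl and inhibition fell strongly. Compound 4 goes the other way, bringing a six-membered aromatic ring back onto the amide-type nitrogen. A rise beyond the scatter is therefore expected, about a number 34.2 percentage points higher from compound 3 to compound 4 (beyond the scatter). The estimate for compound 4 is 8%, between -15% and 32%.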

Compound 4, a percentage reported as inhibition, in the whole organism at one dose (the size of the read-out at that dose, not a potency): 0%
Estimate against measurement, compound 4: 8 percentage points above; low and high end bracket the measured number.
By their numbers in this assay, from the lowest: compound 3; then compounds 4 and 2 (each within the scatter of the next); then compound 1.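

Swapping morpholin-4-yl for 4-aminophenyl on the amide-type nitrogen gives a number 26.2 percentage points higher from compound 3 to compound 4 (beyond the scatter) in this assay, so a six-membered aromatic ring here can recover part of the loss seen with morpholin-4-yl. Recovery is only partial, and the two aromatic groups are not interchangeable: the change from pyridin-2-yl to 4-aminophenyl gives a number 14.6 percentage points lower from compound 1 to compound 4 (beyond the scatter). Nothing available explains either step.

On these data alone, it remains open whether a plain phenyl group, without the amine, would read closer to compound 1 or to compound 4. As far as these compounds go, the effect of a carboxylic acid on that ring also remains open.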